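Swapping Ethoxy for Nitro on a Shared Core

The compounds below may be only part of what the source reports. "The series", "measured", "known", "first", "only" and "open" are said of these compounds alone.

The measurement throughout is an ADME assay on HepG2 cells (Homo sapiens) for cytotoxicity, read by luminescence, with a stated time of 72 h; on this read-out lower numbers stand for an effect already at smaller amounts and higher numbers for an effect only at larger amounts of compound. Compound 1, `CCOC(=O)c1c(-c2cccc(-c3ccccc3)c2)[nH]c2cc(OC)ccc2c1=O`, and compound 2, `CCOC(=O)c1c(-c2cccc(OCC)c2)[nH]c2cc(OC)ccc2c1=O`, share one core and differ in a single group. In this assay compound 1 gives > 21500 nM, which is a limit of the assay rather than a number. In this assay compound 2 likewise gives > 21500 nM, again a limit and not a measured number. The step that the two limits leave unreadable from compound 1 to compound 2 therefore cannot be read; the limit of > 21500 nM in this assay, at which 2 of the 2 values shown sit, shows both values sitting at the same limit. Compound 2 thus stands at that limit, with no number that would place it against any other compound.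

Compound 3, `CCOC(=O)c1c(-c2cccc([N+](=O)[O-])c2)[nH]c2cc(OC)ccc2c1=O`, is the compound still to be measured. Its change from compound 2 is nitro in place of ethoxy on an aromatic carbon. No readable measured step bears on this change. With both known values at the limit, no step beyond the scatter is expected in this assay in either direction. The expected step that the limit leaves unreadable from compound 2 to compound 3 is accordingly small. Compound 3 is therefore expected to give about 25000 nM, with a range from 10000 nM to 60000 nM, and most likely to be reported once more only as a limit.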

Compound 3, half-maximal effective concentration: > 21500 nM
Compound 3: no number, only a limit (the forecaster's own chance of this, stated with the estimate: 75%); the middle value lies beyond the limit too.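

No step can be read among compound 1, compound 2 and compound 3, because each is reported only as a limit and not as a number: the limit of > 21500 nM in this assay, at which 3 of the 3 values shown sit.

The compounds shown leave open how phenyl, ethoxy and nitro on the shared core compare in this assay, and at what amount of compound, if any, each would show an effect.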